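This account rests on a few compounds, and the source may have more. Where it says the series, first, only, none or still open, it means among the compounds named here.

Of the compounds shown here, three carrying the same core have been measured in an assay on isolated protein for inhibition of protein kinase C zeta type (Homo sapiens), with stated times of 1 h and 2.5 min, tested at 30 uM; a higher number here means more inhibition at the concentration tested (going by the name of the read-out), a lower number less inhibition. Compound 1, `CCOC(=O)c1cscc1-c1ccc(OC)c(OC)c1`, lacks the amino group found in the other two, and in this assay compound 1 gives 3%. Compound 2, `COc1ccc(-c2csc(N)c2C(=O)Oc2ccccc2)cc1OC`, gives 48% in this assay, and compound 3, `COc1ccc(-c2csc(N)c2C(=O)OCc2ccc(C)cc2)cc1OC`, gives 50%. Compound 2 thus stands second highest of the three numbers: compound 3 lies nearest, with a number 2 percentage points higher from compound 2 to compound 3 (within the scatter), while compound 1 lies far below it, its value being a great deal lower than that of compound 2.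

The unmeasured compound 4 is `COc1ccc(-c2csc(N)c2C(=O)NCc2ccncc2)cc1OC`. Relative to compound 2 it differs in one place: ((pyridin-4-yl)methyl)amino in place of phenoxy on a carbonyl carbon. Within the data shown here, only one measured step touches this part of the molecule, the change from compound 2 to compound 3, and that step was a number 2 percentage points higher from compound 2 to compound 3 (within the scatter), a change within the scatter. Among the measured compounds shown here, no measured pair exchanges the oxygen of that position for a nitrogen, so the present change is not covered by any step seen so far. On this basis compound 4 is expected to stay near compound 2, with a step of about a number 2 percentage points higher from compound 2 to compound 4 (within the scatter), which would be within the scatter. The estimate for compound 4 in this assay is therefore 50%, within a range from 28% to 72%.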

Compound 4, a percentage reported as inhibition, at one concentration (the size of the read-out at that concentration, not a potency): 3%
Compound 4: the middle estimate sits 47 percentage points above what was measured; the measured number lies below the stated range.
By their numbers in this assay, from the lowest: compounds 1 and 4 (each within the scatter of the next); then compounds 2 and 3 (each within the scatter of the next).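

Exchanging phenoxy for (4-methylbenzyl)oxy moved the number by no more than the scatter, but in this assay the group on this carbonyl carbon proves able to matter a great deal: ((pyridin-4-yl)methyl)amino in place of phenoxy gives a number 45 percentage points lower from compound 2 to compound 4 (beyond the scatter), and in place of (4-methylbenzyl)oxy it gives a number 47 percentage points lower from compound 3 to compound 4 (beyond the scatter). These steps bundle several differences, since the group entering in place of phenoxy links through nitrogen instead of oxygen, carries a six-membered aromatic ring with 1 hetero atom instead of a ring of carbon only, and adds a hydrogen-bond donor, so the compounds cannot assign the loss to any one of these features. Nothing available explains why this exchange has so large an effect.

The compounds shown leave open whether the linking nitrogen or the ring nitrogen accounts for the step: benzylamino would keep the linking nitrogen with a ring of carbon only, while (pyridin-4-yl)methoxy would keep the ring nitrogen with a linking oxygen. They also leave open how a smaller group such as methylamino, or a carboxylic acid at this carbonyl carbon, would read in this assay.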